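Methyl for fluoro on the benzyl ring of compound 1

The source may hold more compounds than are shown below. What is called first, only, known or untested is meant among the compounds shown, and "the series" means these compounds.

Compound 1 `O=C(/C(=C\c1c[nH]c2ccc(Br)cc12)SCc1ccc(F)cc1)c1ccc(Cl)cc1` gives 50000 nM in a functional assay on DU-145 cells (Homo sapiens) for inhibition, read by trypan blue exclusion, with a stated time of 96 h; on this read-out higher numbers stand for weaker inhibition of growth and lower numbers for stronger inhibition of growth.
Compound 2 `O=C(/C(=C\c1c[nH]c2ccccc12)SCc1ccc(F)cc1)c1ccc(Cl)cc1` gives 1000 nM in this assay.
Compound 3 `Cc1ccc(/C=C(/SCc2ccc(F)cc2)C(=O)c2ccc(Cl)cc2)s1` gives > 100000 nM in this assay, which is a limit of the assay rather than a number.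

Among the two numbers, compound 1 stands highest; the step of a 50-fold lower number from compound 1 to compound 2 (1.70 log units; beyond the scatter) separates it from compound 2. Compound 4 `Cc1ccc(CS/C(=C/c2c[nH]c3ccc(Br)cc23)C(=O)c2ccc(Cl)cc2)cc1` differs from compound 1 in one place: methyl in place of fluoro on an aromatic carbon. The measured steps, a 50-fold lower number from compound 1 to compound 2 (1.70 log units; beyond the scatter) and an at least 100-fold higher number from compound 2 to compound 3 (2.00 log units; beyond the scatter), both alter the group on the double-bonded chain carbon, not the benzyl ring, so none of them bears on this change. No step beyond the scatter is therefore expected in this assay. Compound 4 is estimated at 50000 nM, between 15000 nM and 150000 nM, an expected step of no change at the digits printed from compound 1 to compound 4 (within the scatter).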

Compound 4, concentration for 50% growth inhibition: 1000 nM
Estimate against measurement, compound 4: 50-fold (1.70 log units) above; measured number outside the range, below it.
By their numbers in this assay, from the lowest: compounds 2 and 4 (each within the scatter of the next); then compound 1. At a limit, above all of these: compound 3.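

Compounds 1 to 3 all carry the 4-fluorobenzyl group, so they say nothing about this ring, whereas 4-methylbenzyl in its place gives a 50-fold lower number from compound 1 to compound 4 (1.70 log units; beyond the scatter) in this assay. The position is therefore sensitive: exchanging one heavy atom for another at this place, para to a large group, is enough for a large step. Nothing measured here explains why this swap matters.

From the compounds shown here alone, whether methyl would act the same way on compound 2, which has hydrogen in place of bromo, remains open. So does the outcome with an amine or a carboxylic acid at this place.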